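The source may hold more compounds than are shown below. What is called first, only, known or untested is meant among the compounds shown, and "the series" means these compounds.

Measured so far in a functional assay on MCF7 cells (Homo sapiens) for inhibition, read by sulforhodamine B assay, with a stated time of 72 h; a higher number here means a weaker inhibitor, a lower number a stronger inhibitor:

Compound 1, `COc1ccc(C(=O)/C=C/c2cn(-c3ccccc3)nc2-c2cccnc2)c(OC)c1`: 2300 nM
Compound 2, `O=C(/C=C/c1cn(-c2ccccc2)nc1-c1ccncc1)c1cc[nH]c1`: 13600 nM
Compound 3, `COc1cc(OC)c(C(=O)/C=C/c2cn(-c3ccccc3)nc2-c2ccncc2)c(OC)c1`: 1600 nM

Compound 3 holds the lowest of the three numbers in this assay. Its nearest neighbour is compound 1, whose value lies within the usual scatter of compound 3, so the two cannot be told apart. Compound 2 stands well beyond the scatter, with a clearly higher number.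

Compound 4, `COc1ccc(C(=O)/C=C/c2cn(-c3ccccc3)nc2-c2ccncc2)c(OC)c1`, is not yet measured. It differs from compound 3 in one place: hydrogen in place of methoxy on an aromatic carbon. After this change, the six-membered aromatic ring of carbon only in compound 4 carries the same two methoxy groups as the corresponding ring in compound 1, while the rest of the structure stays as in compound 3. Among the compounds with values here, no measured pair shows this exact step, so the expectation rests on compound 1 and compound 3 lying within the scatter of each other. The step from compound 3 to compound 4 is therefore expected to be small, a 1.4-fold higher number from compound 3 to compound 4 (0.14 log units; within the scatter), not beyond the scatter in either direction. Compound 4 is expected to give about 2200 nM in this assay, somewhere between 1000 nM and 5000 nM.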

Compound 4, half-maximal inhibitory concentration: 8800 nM
The estimate for compound 4 lay 4.0-fold (0.60 log units) below the measured number; measured number outside the range, above it.
By their numbers in this assay, from the lowest: compounds 3 and 1 (each within the scatter of the next); then compounds 4 and 2 (each within the scatter of the next).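

In this assay the methoxy group on the aromatic carbon ortho to a large group matters: hydrogen in its place gives a 5.5-fold higher number from compound 3 to compound 4 (0.74 log units; beyond the scatter) and so a clear loss of inhibition. The attachment of the pyridine also counts with 2,4-dimethoxyphenyl on the carbonyl carbon, as pyridin-4-yl in place of pyridin-3-yl gives a 3.8-fold higher number from compound 1 to compound 4 (0.58 log units; beyond the scatter) and this too is beyond the scatter. By contrast, 2,4-dimethoxyphenyl in place of 1H-pyrrol-3-yl on a carbonyl carbon gives a 1.5-fold lower number from compound 2 to compound 4 (0.19 log units; within the scatter) and cannot be told apart from no change.

No measurement at hand gives a reason for the size of these steps. Still open, from the compounds shown here alone, is whether a hydroxyl group or an amine at this place would match methoxy, and whether removing this methoxy costs as much in a compound carrying pyridin-3-yl.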